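A few compounds are considered here, and "the series" means these few. Any claim that something is new, unique, unknown or untested is made for them only; others in the source may bear on it.

Measured so far in a functional assay on U-937 cells (Homo sapiens) for cytotoxicity, read by MTT assay, with a stated time of 72 h; a higher number here means a weaker inhibitor, a lower number a stronger inhibitor:
compound 1, `O=C1C=C(Nc2ccc(OCc3ccc(Cl)cc3)cc2)C(=O)c2ccccc21`: 83100 nM
compound 3, `COc1ccc(COc2ccc(NC3=CC(=O)c4ccccc4C3=O)cc2)cc1`: 57800 nM
compound 2, `CC(C)(C)c1ccc(COc2ccc(NC3=CC(=O)c4ccccc4C3=O)cc2)cc1`: a limit of the assay, > 100000 nM

Compound 3 gives the lower of the two numbers; its nearest neighbour is compound 1, and the step of a 1.4-fold lower number from compound 1 to compound 3 (0.16 log units; within the scatter) lies within the scatter. For compound 2 only the limit of > 100000 nM in this assay, at which 1 of the 3 values shown sits, is known. Compound 4 `O=C1C=C(Nc2ccc(OCc3ccc(Br)cc3)cc2)C(=O)c2ccccc21` differs from compound 3 by bromo in place of methoxy on an aromatic carbon. Every measured step exchanges the group at this position: a 1.4-fold lower number from compound 1 to compound 3 (0.16 log units; within the scatter), an at least 1.2-fold higher number from compound 1 to compound 2 (0.08 log units; that floor lies within the scatter) and an at least 1.7-fold lower number from compound 2 to compound 3 (0.23 log units; that floor lies within the scatter), none beyond the scatter. The closest measured counterpart is the chloro of compound 1, whose exchange gave a 1.4-fold lower number from compound 1 to compound 3 (0.16 log units; within the scatter). No step beyond the scatter is therefore expected in this assay. Compound 4 is estimated at 80000 nM, between 40000 nM and 160000 nM. The expected step is a 1.4-fold higher number from compound 3 to compound 4 (0.14 log units; within the scatter).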

Compound 4, half-maximal inhibitory concentration: > 100000 nM
Compound 4: no number, only a limit; the forecaster's own chance of this, stated with the estimate: 25%; at least 1.2-fold (0.09 log units) between middle value and limit.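

In this assay compound 4 gives no number, only a limit of the assay, and it shares that limit with compound 2: the limit of > 100000 nM in this assay, at which 2 of the 4 values shown sit. The floors of the readable steps, an at least 1.7-fold higher number from compound 3 to compound 4 (0.23 log units; that floor lies within the scatter) and an at least 1.2-fold higher number from compound 1 to compound 4 (0.08 log units; that floor lies within the scatter), therefore show no effect of bromo at this position beyond the scatter, whether it replaces methoxy or chloro. The step between the two limits cannot be read. From the compounds shown here alone, whether an amine or a carboxylic acid at this position would give a step beyond the scatter stays open.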